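The compounds below may be only part of what the source reports. "The series", "measured", "known", "first", "only" and "open" are said of these compounds alone.

Working notes on the series. Three compounds have numbers in a physicochemical assay for lipophilicity (on this read-out lower numbers stand for lower lipophilicity and higher numbers for higher lipophilicity), so far: compound 1 `CC#CCOC(=O)/C=C(C)/C=C/CC(C)CCCC(C)C`, compound 2 `COC(C)(C)CCCC(C)C/C=C/C(C)=C/C(=O)OCCC(C)C` and compound 3 `CCOC(=O)/C=C(C)/C=C/CC(C)CCCC(C)(C)OCC`. In this assay compound 1 gives 6.4, compound 2 gives 7.03 and compound 3 gives 6.08. Compound 1 stands second highest of the three; compound 3 lies below it, beyond the scatter, and compound 2 above it, further away and also beyond the scatter.

Compound 4 `CCN(CC)C(=O)/C=C(C)/C=C/CC(C)CCCC(C)C` is not yet measured in this assay. It differs from compound 1 in one place: diethylamino in place of (but-2-yn-1-yl)oxy on a carbonyl carbon. For the measured compounds named here, no step of this kind has been measured, so the expectation rests on the structural change alone. A downward step in this assay is expected from compound 1 to compound 4, of the size a number 0.80 log units lower from compound 1 to compound 4 (beyond the scatter), which would be beyond the scatter. For compound 4 the estimate in this assay is 5.6, with a range from 5 to 6.2.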

Compound 4, partition coefficient: 6.02
Compound 4: middle estimate off by 0.42 log units, on the low side; measured number inside the range.
By their numbers in this assay, from the lowest: compounds 4 and 3 (each within the scatter of the next); then compound 1; then compound 2.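

In this assay, for the compounds shown here, diethylamino in place of (but-2-yn-1-yl)oxy on a carbonyl carbon gives the first single-place step: a number 0.38 log units lower from compound 1 to compound 4 (beyond the scatter). The position therefore responds to this exchange, even though the heavy-atom count of the group stays the same while oxygen and the triple bond leave and nitrogen enters. The compounds shown carry no independent measurement that bears on the origin of this step.

Open, from the compounds shown here alone, is how much of the step goes with the triple bond and how much with the exchange of oxygen for nitrogen, a question that butoxy on the same carbonyl carbon could separate from compound 1. Also open, going by these compounds, is how other groups at this position, such as dimethylamino or a carboxylic acid, would read in this assay.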